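Aryl amide variation at the cyclopropane dicarboxamide terminus

A few compounds are considered here, and "the series" means these few. Any claim that something is new, unique, unknown or untested is made for them only; others in the source may bear on it.

Compound 2 `CN(C)C(=O)c1cc2cnc(Nc3ccc(NC(=O)C4(C(=O)Nc5cccc(O)c5)CC4)cc3)nc2n1C1CCCC1` gives 86% in a functional assay on OVCAR-5 cells (Homo sapiens) for inhibition, read by CCK-8 assay, with a stated time of 72 h, tested at 10 uM; on this read-out lower numbers stand for less inhibition of growth and higher numbers for more inhibition of growth at the one concentration tested. It stands highest of the three numbers available, but its nearest neighbour, compound 1 `CN(C)C(=O)c1cc2cnc(Nc3ccc(NC(=O)C4(C(=O)Nc5ccccc5F)CC4)cc3)nc2n1C1CCCC1` with 82.6%, sits within the scatter of it, so no order between these two is claimed. Within the data shown here, the furthest of the three is compound 3 `CN(C)C(=O)c1cc2cnc(Nc3ccc(NC(=O)C4(C(=O)Nc5ccc(F)cc5)CC4)cc3F)nc2n1C1CCCC1`, which in this assay gives 33%; compound 3 differs from compound 2 in two places and no single step to it is available, so its value is noted only as it stands.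

Compound 4 `CN(C)C(=O)c1cc2cnc(Nc3ccc(NC(=O)C4(C(=O)Nc5ccc(Cl)c(C(F)(F)F)c5)CC4)cc3)nc2n1C1CCCC1` is not yet measured. Its difference from compound 2 is 4-chloro-3-(trifluoromethyl)phenyl in place of 3-hydroxyphenyl on an amide-type nitrogen.

Among the measured compounds shown here, the one measured step touching the same place is a number 3.4 percentage points higher from compound 1 to compound 2 (within the scatter), where one aryl group replaced another on the amide-type nitrogen and the read-out did not move beyond the scatter. For the measured compounds named here, that is the sole guide; the large gap to compound 3 cannot be assigned to the aryl group alone. Compound 4 is therefore expected to stay close to compound 2, with a step of a number 10 percentage points lower from compound 2 to compound 4 (within the scatter) in this assay not exceeding the scatter. The estimate for compound 4 is 76%, with a range from 45% to 92%.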

Compound 4, percent growth inhibition at one concentration: 48%
Estimate against measurement, compound 4: 28 percentage points above; the range from low to high includes it.
By their numbers in this assay, from the lowest: compound 3; then compound 4; then compounds 1 and 2 (each within the scatter of the next).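

In this assay this amide-type nitrogen proves sensitive to the choice of aryl group: the earlier exchange of one aryl group for another stayed within the scatter, whereas 4-chloro-3-(trifluoromethyl)phenyl gives a number 38 percentage points lower from compound 2 to compound 4 (beyond the scatter) and a number 34.6 percentage points lower from compound 1 to compound 4 (beyond the scatter) as its two steps. The drop therefore appears against both 3-hydroxyphenyl and 2-fluorophenyl, so not every aryl group on this nitrogen holds the read-out, although the exchange with 3-hydroxyphenyl changes several things at once: 11 heavy atoms replace 7, and 0 hydrogen-bond donors and 0 acceptors replace 1 of each. No measurement on hand bears on the reason for the drop, which remains unassigned.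

The compounds shown do not separate the contributions of the chlorine and the trifluoromethyl group, since the two occur only together, and a phenyl carrying just one of them would be the direct test. Also open, on these data alone, is how this position responds when an amine or a carboxylic acid takes the place of the hydroxyl group of compound 2.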